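From Methoxy to Cyclopentylsulfanyl in a Well-Tolerated Series

The source may hold more compounds than are shown below. What is called first, only, known or untested is meant among the compounds shown, and "the series" means these compounds.

In an ADME assay on cells (Fibroblast, Gallus gallus) for cytotoxicity, read by CCK-8 assay, with a stated time of 48 h (a higher number here means that more compound is tolerated, a lower number that less compound is tolerated), compound 3 `CCC(CC)O[C@@H]1C=C(C(=O)O)C[C@H](NCc2cccc(OC)c2)[C@H]1NC(C)=O` gives > 200000 nM as a limit of the assay and not a number. Compound 1 `CCc1ccc(CN[C@H]2CC(C(=O)O)=C[C@@H](OC(CC)CC)[C@@H]2NC(C)=O)cc1` gives > 200000 nM as a limit as well. Compound 2 `CCC(CC)O[C@@H]1C=C(C(=O)O)C[C@H](NCc2ccc(C(C)(C)C)cc2)[C@H]1NC(C)=O` also gives > 200000 nM as a limit. The evidence so far is therefore the limit of > 200000 nM in this assay, at which 3 of the 3 values shown sit, with no exact number behind it.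

Compound 4 `CCC(CC)O[C@@H]1C=C(C(=O)O)C[C@H](NCc2cccc(SC3CCCC3)c2)[C@H]1NC(C)=O` carries cyclopentylsulfanyl in place of methoxy on an aromatic carbon, a swap counted as cyclopentylsulfanyl in place of methoxy on an aromatic carbon in full. Going by the values given here, three measured steps bear on this swap. They are a step that the two limits leave unreadable from compound 1 to compound 2 for tert-butyl in place of ethyl, then a step that the two limits leave unreadable from compound 1 to compound 3 and a step that the two limits leave unreadable from compound 2 to compound 3 for the two exchanges of the substituted phenyl group. Among the compounds with values here, none has a readable size, so they show only that all three compounds stay at the limit.

Cyclopentylsulfanyl itself is untested here, so a modest fall in the tolerated concentration remains possible. No change beyond the usual scatter is expected, and the estimated step is a number no higher from compound 3 to compound 4 (the limit leaves the size open) in this assay overall. For compound 4 the estimated half-maximal cytotoxic concentration is 200000 nM with an expected range from 80000 nM to 400000 nM in this estimate.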

Compound 4, half-maximal cytotoxic concentration: > 200000 nM
Compound 4 gave a limit, no number (the forecaster's own chance of this, stated with the estimate: 70%); the middle value sits exactly at the limit.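

In this assay compound 4 gives > 200000 nM, a limit of the assay and not a number. Going by these compounds alone, compound 3 also stands at a limit, so no step between the two can be read. Still open is where the true tolerated concentration of each compound lies, and whether any swap shifts it, with the evidence still only this: the limit of > 200000 nM in this assay, at which 4 of the 4 values shown sit.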